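Dropping the tert-butyl group from compound 2

This account rests on a few compounds, and the source may have more. Where it says the series, first, only, none or still open, it means among the compounds named here.

Values in a functional assay on NCI-H460 cells (Homo sapiens) for cytotoxicity, read by MTT assay, with a stated time of 72 h; on this read-out higher numbers stand for weaker inhibition and lower numbers for stronger inhibition:
compound 1 `CCN(CC)Cc1ccc2nc(NC(=O)N/N=C/c3cn(Cc4ccc(C(C)(C)C)cc4)c4ccccc34)sc2c1`: 1670 nM
compound 2 `CN(C)Cc1ccc2nc(NC(=O)N/N=C/c3cn(Cc4ccc(C(C)(C)C)cc4)c4ccccc34)sc2c1`: 810 nM
compound 3 `CC1CCN(Cc2ccc3nc(NC(=O)N/N=C/c4c[nH]c5ccccc45)sc3c2)CC1`: 4130 nM

Of these three, compound 2 has the lowest number, 810 nM, which means the strongest inhibition. Compound 4 `CN(C)Cc1ccc2nc(NC(=O)N/N=C/c3cn(Cc4ccccc4)c4ccccc34)sc2c1` carries hydrogen in place of tert-butyl on an aromatic carbon. Within the data shown here, the only measured single change, a 2.1-fold lower number from compound 1 to compound 2 (0.31 log units; beyond the scatter), is modest and concerns a different group, dimethylamino in place of diethylamino. It therefore offers only a rough guide to how large one change can be in this series. Among the measured compounds shown here, no measured step shows the loss of tert-butyl itself. A modest step to a higher number is expected in this assay, a 1.5-fold higher number from compound 2 to compound 4 (0.17 log units; within the scatter). The estimate for compound 4 is 1200 nM, with an expected range from 400 nM to 3500 nM.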

Compound 4, half-maximal inhibitory concentration: 400 nM
The estimate for compound 4 lay 3.0-fold (0.48 log units) above the measured number, within the range that was stated.
By their numbers in this assay, from the lowest: compound 4; then compound 2; then compound 1; then compound 3.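

In this assay replacing 4-(tert-butyl)benzyl with plain benzyl gives a 2.0-fold lower number from compound 2 to compound 4 (0.31 log units; beyond the scatter) and shows that the tert-butyl group is not needed here: the number falls without it. Among these compounds, this is the first measured change at this position, and its size is modest. Nothing available explains the gain.

From the compounds shown here alone, whether methyl, a fluorine atom, an amine or a carboxylic acid at this place would lower the number further remains open. So does whether the same change would act alike with the diethylamino group of compound 1.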